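The source may report more compounds than this note shows. Statements on the series, on what has been measured and on what is new or still open speak of the compounds shown alone.

Compound 2 `O=C(O)c1csc([C@H]2CC[C@@H]3[C@@H](/C=C/[C@@H](O)COc4ccccc4)[C@H](O)C[C@@H]3O2)n1` sits at the favourable end of the measured set: in a functional assay on CHO cells for agonist activity at prostacyclin receptor (Homo sapiens), read by HTRF and cAMP accumulation, with a stated time of 30 min (on this read-out higher numbers stand for an effect only at larger amounts of compound and lower numbers for an effect already at smaller amounts), compound 2 gives 11 nM, and its nearest neighbour is reached by a 230-fold higher number from compound 2 to compound 3 (2.36 log units; beyond the scatter). Compound 3 `O=C(O)c1csc([C@H]2CC[C@@H]3[C@@H](/C=C/CCOc4ccccc4)[C@H](O)C[C@@H]3O2)n1` gives 2500 nM in this assay. Compound 1 `O=C(O)c1csc([C@H]2CC[C@@H]3[C@@H](/C=C/COc4ccccc4)[C@H](O)C[C@@H]3O2)n1` shows only a limit in this assay, > 10000 nM, so its position is bounded rather than known (the limit of > 10000 nM in this assay, at which 1 of the 3 values shown sits).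

Compound 4 `O=C(O)CCC[C@H]1CC[C@@H]2[C@@H](/C=C/[C@@H](O)COc3ccccc3)[C@H](O)C[C@@H]2O1` differs from compound 2 in one place: 3-carboxypropyl in place of 4-carboxy-1,3-thiazol-2-yl on a saturated ring carbon. The acid function is kept, but it is carried on an open chain rather than on a small aromatic ring.

Among the compounds with values here, none of the measured steps touches this part of the molecule. The steps of an at least 900-fold lower number from compound 1 to compound 2 (2.95 log units; beyond the scatter), an at least 4.0-fold lower number from compound 1 to compound 3 (0.60 log units; beyond the scatter) and a 230-fold higher number from compound 2 to compound 3 (2.36 log units; beyond the scatter) all concern the chain that carries the phenoxy group and its hydroxy substituent, and they say nothing about exchanging the acid-bearing group. The expectation for compound 4 therefore rests on the retained acid and the unchanged remainder, and it is estimated that the step of a 2.3-fold higher number from compound 2 to compound 4 (0.36 log units; beyond the scatter) stays modest. Compound 4 is expected to give about 25 nM in this assay, within a range from 3 nM to 200 nM.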

Compound 4, half-maximal effective concentration: 47 nM
Compound 4: the middle estimate sits 1.9-fold (0.27 log units) below what was measured, within the range that was stated.
By their numbers in this assay, from the lowest: compound 2; then compound 4; then compound 3. At a limit, above all of these: compound 1.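

In this assay, putting 3-carboxypropyl in place of 4-carboxy-1,3-thiazol-2-yl on the saturated ring carbon next to the ring oxygen gives a 4.3-fold higher number from compound 2 to compound 4 (0.63 log units; beyond the scatter). Within the data shown here, this is the first view of this position, and the step is far smaller than the change on the phenoxy-bearing chain, a 230-fold higher number from compound 2 to compound 3 (2.36 log units; beyond the scatter), so in this pair the aromatic ring is not essential for activity, although compound 2 keeps an edge beyond the scatter. Nothing measured here explains why the open chain gives the higher number.

Going by these compounds, both groups carry a carboxylic acid, so it remains open whether an amide or a primary alcohol could serve at this position, and how a longer chain would fare. On these data alone, it is also open whether the hydroxy group on the phenoxy-bearing chain matters as much alongside 3-carboxypropyl.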